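Trading a hydroxyl for two methyls on the sulfur chain

The source may hold more compounds than are shown below. What is called first, only, known or untested is meant among the compounds shown, and "the series" means these compounds.

Of the compounds shown here, three sharing one core have been measured in a functional assay on HT cells (Homo sapiens) for antiproliferative activity, read by fluorescence, with a stated time of 72 h; a higher number here means a weaker inhibitor of growth, a lower number a stronger inhibitor of growth. Compound 1 `CC(C)c1n[nH]c2c(NCc3ccc(-c4ccccn4)cc3)nc(SCC(O)CN)nc12` gives 55 nM. Compound 2 `CC(C)c1n[nH]c2c(NCc3ccc(-c4ccccn4)cc3)nc(SC[C@H](O)CN)nc12`, which differs from it only in that a stereocentre is drawn with a configuration (the fact that one of compounds 1 and 2 is drawn with a defined configuration and the other without, at the place where they differ), gives 63 nM in this assay, the step being a 1.1-fold higher number from compound 1 to compound 2 (0.06 log units; within the scatter). Compound 3 `CC(C)c1n[nH]c2c(NCc3ccc(-c4ccccn4)cc3)nc(SC3CCCCC3N)nc12` gives 139 nM in this assay, so the step from compound 2 is a 2.2-fold higher number from compound 2 to compound 3 (0.34 log units; beyond the scatter). Compound 2 thus sits close to compound 1 and well below compound 3.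

Compound 4 `CC(C)c1n[nH]c2c(NCc3ccc(-c4ccccn4)cc3)nc(SCC(C)(C)N)nc12` has not been measured. Its difference from compound 2 is 1-amino-1-methylethyl in place of 2-amino-1-hydroxyethyl on a saturated chain carbon bound to a sulfur. Among the measured compounds shown here, the only measured step that bears on this is a 2.2-fold higher number from compound 2 to compound 3 (0.34 log units; beyond the scatter), which likewise replaces the 3-amino-2-hydroxypropyl group on the sulfur, giving a modest rise. A similar modest rise seems likely here, though the entering group is different, so the range is kept wide. Compound 4 is therefore expected to give 110 nM, between 45 nM and 280 nM. That estimate means an expected step of a 1.7-fold higher number from compound 2 to compound 4 (0.24 log units; within the scatter).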

Compound 4, concentration for 50% growth inhibition: 85 nM
Compound 4: the middle estimate sits 1.3-fold (0.11 log units) above what was measured; measured number inside the range.
By their numbers in this assay, from the lowest: compounds 1, 2, 4 and 3 (each within the scatter of the next, the first and the last beyond it).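

In this assay, replacing 3-amino-2-hydroxypropyl on the sulfur with 2-amino-2-methylpropyl removes the hydroxyl and the defined stereocentre in one change, yet the result stays within the scatter of both hydroxyl compounds (a 1.3-fold higher number from compound 2 to compound 4 (0.13 log units; within the scatter); a 1.5-fold higher number from compound 1 to compound 4 (0.19 log units; within the scatter)). This position therefore keeps a number of this size without any hydroxyl on the chain, at least for this one replacement. Compound 3 lay beyond the scatter from compounds 1 and 2, but 2-amino-2-methylpropyl cannot be separated from its 2-aminocyclohexyl either (a 1.6-fold lower number from compound 3 to compound 4 (0.21 log units; within the scatter)), and nothing shown bears on the reason for any of this.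

From the compounds shown here alone, the hydroxyl leaves and the two methyls enter in a single step, and the share of each stays open. Also open, going by these compounds, is how a plain 2-aminoethyl chain on the sulfur, carrying neither, would compare, or a carboxylic acid in place of the amine.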